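The compounds below may be only part of what the source reports. "The series", "measured", "known", "first", "only" and "open" are said of these compounds alone.

The set shares one core and is tested in a functional assay on L1210 (1565) cells (Mus musculus) for cytotoxicity; a higher number here means that more compound is needed for the effect, a lower number that less compound is needed. Compound 1, `Oc1cc(-c2ccccc2)nc2c(O)cccc12`, gives only a limit in this assay, > 10 ug/mL. Compound 2, `CC(C)COc1cc(-c2ccccc2)nc2ccccc12`, likewise returns only a limit, > 10 ug/mL, so that its standing among the numbers shown is bounded rather than fixed. Two of the three values sit at the limit of > 10 ug/mL in this assay, at which 2 of the 3 values shown sit. Going by the values given here, compound 3, `Oc1cc(-c2ccccc2)nc2cc(F)ccc12`, is the one member with a number, giving 0.16 ug/mL in this assay. The unmeasured compound 4, `CS(=O)(=O)Oc1cc(-c2ccccc2)nc2ccccc12`, differs from compound 2 by methylsulfonyl in place of isobutyl on an oxygen on an aromatic ring. Among the compounds with values here, no step between measured compounds is at hand to gauge this change. Compound 4 is expected to give 5 ug/mL, within a range from 1 ug/mL to 20 ug/mL. The expected step of an at least 2.0-fold lower number from compound 2 to compound 4 (0.30 log units; that floor lies within the scatter) would run toward a lower number, though modestly, and a limit may well be reported again.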

Compound 4, half-maximal effective concentration: 6.04 ug/mL
Compound 4: middle estimate off by 1.2-fold (0.08 log units), on the low side; low and high end bracket the measured number.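

Compound 4 gives this oxygen on an aromatic ring a real number in this assay, where compound 2 offered only a limit, so the exchange of isobutyl for methylsulfonyl can now be bounded from one side. The change amounts to an at least 1.6-fold lower number from compound 2 to compound 4 (0.21 log units; that floor lies within the scatter), so its floor alone does not establish a real difference. Limits still make up much of the set: the limit of > 10 ug/mL in this assay, at which 2 of the 4 values shown sit.

On these data alone, the true size of the step stays open, since one end of it is a limit. Also open, as far as these compounds go, is how an acetyl or a benzyl group on the same oxygen would read.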